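Amine Replacement on the Saturated Ring Carbon: Compound 4 Expected

The compounds below may be only part of what the source reports. "The series", "measured", "known", "first", "only" and "open" are said of these compounds alone.

Measured compounds in a functional assay on CHO cells for activation of 5-hydroxytryptamine receptor 1D (Homo sapiens), read by GTPgammaS binding; a higher number here means a larger maximal response, a lower number a smaller maximal response:
Compound 1, `CN(Cc1cccs1)C1CCN(CCCc2c[nH]c3ccc(-n4cnnc4)cc23)CC1`, gives 81%.
Compound 2, `OCCC(NC1CCN(CCCc2c[nH]c3ccc(-n4cnnc4)cc23)CC1)c1ccccc1`, gives 100%.
Compound 3, `CN(Cc1ccsc1)C1CCN(CCCc2c[nH]c3ccc(-n4cnnc4)cc23)CC1`, gives 93%.

Compound 3 stands second highest of the three; its nearest neighbour is compound 2, within the scatter, and its furthest is compound 1, beyond the scatter. Compound 4, `c1ccc2c(c1)CCC2NCC1CCN(CCCc2c[nH]c3ccc(-n4cnnc4)cc23)CC1`, differs from compound 3 as follows: ((2,3-dihydro-1H-inden-1-yl)amino)methyl in place of methyl((thiophen-3-yl)methyl)amino on a saturated ring carbon. Two measured steps exchange the whole group on the same saturated ring carbon: a number 19 percentage points higher from compound 1 to compound 2 (beyond the scatter) and a number 7 percentage points lower from compound 2 to compound 3 (within the scatter). Both are modest or within the scatter, and all three amines sit high in this assay. Compound 4, like compound 2, carries one hydrogen-bond donor; the expected step is therefore a number 1 percentage points lower from compound 3 to compound 4 (within the scatter). For compound 4 the estimate is 92%, within 76% to 106%.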

Compound 4, largest response reached (reported as efficacy), in percent of the reference or control that the assay uses: 78%
Estimate against measurement, compound 4: 14 percentage points above; the measured number falls inside the stated range.
By their numbers in this assay, from the lowest: compounds 4 and 1 (each within the scatter of the next); then compounds 3 and 2 (each within the scatter of the next).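

In this assay, the ((2,3-dihydro-1H-inden-1-yl)amino)methyl group shows that not every amine on this saturated ring carbon keeps the response high: a number 15 percentage points lower from compound 3 to compound 4 (beyond the scatter) and a number 22 percentage points lower from compound 2 to compound 4 (beyond the scatter). A hydrogen-bond donor in this group does not hold the response at the level of compound 2, while a number 3 percentage points lower from compound 1 to compound 4 (within the scatter) leaves it level with the thiophen-2-yl amine. Nothing available accounts for these steps. Still open, on these data alone, is whether they follow the 2,3-dihydro-1H-inden-1-yl ring or its aminomethyl link. A (2,3-dihydro-1H-inden-1-yl)amino group directly on the ring carbon, or a benzylaminomethyl group, would separate the two.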